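Cinnamamide quinoline series: methyl-for-hydrogen steps

This account rests on a few compounds, and the source may have more. Where it says the series, first, only, none or still open, it means among the compounds named here.

Compound 1 `CCCc1cc(N)c2cc(NC(=O)/C=C/c3ccc(CC)cc3)ccc2n1` is the reference point; in a functional assay on HEK293 cells for activation of melanin-concentrating hormone receptor 1 (Homo sapiens), read by inositol phosphate accumulation (on this read-out lower numbers stand for an effect already at smaller amounts and higher numbers for an effect only at larger amounts of compound), compound 1 gives 160 nM. Compound 2 `CCCc1cc(N)c2cc(NC(=O)/C=C/c3ccc(C(C)C)cc3)ccc2n1` carries the change methyl in place of hydrogen on a saturated chain carbon bound to an aromatic carbon and a saturated chain carbon and in this assay compound 2 gives 520 nM, so that the step is a 3.3-fold higher number from compound 1 to compound 2 (0.51 log units; beyond the scatter). Compound 3 `Cc1cc(N)c2cc(NC(=O)/C=C/c3ccc(C(F)(F)F)cc3)ccc2n1` has a different core; the difference between the two cores is not broken down here. In this assay compound 3 gives 140 nM, a number within the scatter of compound 1, so no order between compound 3 and compound 1 can be read from these two values; compound 2 stands beyond the scatter from both.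

Compound 4 `CCc1cc(N)c2cc(NC(=O)/C=C/c3ccc(C(F)(F)F)cc3)ccc2n1` is not yet measured. It carries the change (methyl in place of hydrogen on a saturated chain carbon bound to an aromatic carbon), which, cut one bond further out, reads as methyl to ethyl. Among the compounds with values here, this is the same kind of change as the one from compound 1 to compound 2, but not the same: there the place was a saturated chain carbon bound to an aromatic carbon and a saturated chain carbon, here it is a saturated chain carbon bound to an aromatic carbon only. Within the data shown here, the only measured step of this kind is a 3.3-fold higher number from compound 1 to compound 2 (0.51 log units; beyond the scatter), taken at a different place, so that it is a weak guide. The step from compound 3 to compound 4 in this assay is expected to be a 1.8-fold higher number from compound 3 to compound 4 (0.25 log units; within the scatter), smaller than the earlier one because a 3.3-fold higher number from compound 1 to compound 2 (0.51 log units; beyond the scatter) was made at another position and need not carry over in full. For compound 4 the estimate in this assay is 250 nM, with a likely range from 100 nM to 650 nM.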

Compound 4, half-maximal effective concentration: 110 nM
Beside the measured number, compound 4's estimate is 2.3-fold (0.36 log units) above it; measured number inside the range.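

In this assay, methyl in place of hydrogen on a saturated chain carbon bound to an aromatic carbon gives a 1.3-fold lower number from compound 3 to compound 4 (0.10 log units; within the scatter), so this step sets no order between the two compounds. Set beside the earlier step, the same kind of change does not carry over in size from one core to the other in this series, and a number taken on one core is a poor guide to the other: the same change on two cores in this assay, a 3.3-fold higher number (0.51 log units; beyond the scatter) from compound 1 to compound 2 and a 1.3-fold lower number (0.10 log units; within the scatter) from compound 3 to compound 4, 4.1-fold (0.62 log units) apart, beyond the scatter of two such steps This does not show what lies behind the gap: there is only one step on each core, and the two steps also differ in place, one on a saturated chain carbon bound to an aromatic carbon and a saturated chain carbon, the other on a saturated chain carbon bound to an aromatic carbon only, so the core and the place cannot be told apart.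

Open, going by these compounds, is whether the same methyl step, taken at one and the same place on both cores, would give steps that agree. Also open, on these data alone, is how a longer chain such as butyl, or a chain ending in an amine or a carboxylic acid, would stand in this assay at the saturated chain carbon bound to an aromatic carbon.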